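A few compounds are considered here, and "the series" means these few. Any claim that something is new, unique, unknown or untested is made for them only; others in the source may bear on it.

Compound 2 `S=C(N/N=C/c1ccc2ccccc2n1)Nc1cccc(Br)c1` is one of three analogues tested in a functional assay on HeLa cells (Homo sapiens) for antiproliferative activity, read by sulforhodamine B assay, with a stated time of 72 h; on this read-out lower numbers stand for stronger inhibition and higher numbers for weaker inhibition. Its companion compound 1 `Cc1cccc(NC(=S)N/N=C/c2ccc3ccccc3n2)c1` shares the same core and differs only at the aromatic carbon that carries a methyl group. In this assay compound 1 reaches only the limit of the assay, > 100000 nM, which is a limit and not a number (the limit of > 100000 nM in this assay, at which 1 of the 3 values shown sits). In this assay compound 2 gives 70000 nM, the highest of the two numbers recorded. The third compound, compound 3 `CN(C)C(=S)N/N=C/c1nc2ccccc2s1`, rests on a different core; in this assay compound 3 gives 2100 nM, a value far lower than that of compound 2. For the measured compounds named here, the one measured step, an at least 1.4-fold lower number from compound 1 to compound 2 (0.15 log units; that floor lies within the scatter), is the exchange of the methyl for bromo, and its floor lies within the scatter.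

Compound 4 `S=C(N/N=C/c1ccc2ccccc2n1)Nc1cccc(Cl)c1` differs from compound 2 as follows: chloro in place of bromo on an aromatic carbon. Going by the values given here, no measured step covers a chloro for bromo exchange, and the methyl to bromo step gives no ground for a shift beyond the scatter. Compound 4 is therefore expected to sit near compound 2, with an estimated step of no change at the digits printed from compound 2 to compound 4 (within the scatter). In this assay compound 4 is estimated at 70000 nM, within a range from 25000 nM to 200000 nM.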

Compound 4, half-maximal inhibitory concentration: 52500 nM
For compound 4 the middle estimate is 1.3-fold (0.12 log units) above the measured one, and the stated range covers the measured number.
By their numbers in this assay, from the lowest: compound 3; then compounds 4 and 2 (each within the scatter of the next). At a limit, above all of these: compound 1.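

In this assay, the 3-bromophenyl to 3-chlorophenyl exchange adds a reading of one halogen for another on this aromatic carbon: it gives a 1.3-fold lower number from compound 2 to compound 4 (0.12 log units; within the scatter), so the two halogens cannot be told apart here. The exchange of methyl for chloro at the same place gives an at least 1.9-fold lower number from compound 1 to compound 4 (0.27 log units; that floor lies within the scatter), and this comparison likewise shows no shift beyond the scatter. Compound 1 holds a limit and not a number, so only a floor can be read for this step: the limit of > 100000 nM in this assay, at which 1 of the 4 values shown sits.

The compounds shown leave open whether a group other than methyl, bromo or chloro at this position, such as an amine, a carboxylic acid or a methoxy group, would move the number beyond the scatter. For the compounds shown here, compound 3 differs from the others in more than one place, and no step links it to them.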